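Swapping an aminophenyl for a dichlorophenyl on the chalcone

This account rests on a few compounds, and the source may have more. Where it says the series, first, only, none or still open, it means among the compounds named here.

Compound 1 `COc1cc(-c2cc(/C=C/C(=O)c3ccc(N)cc3)[nH]n2)cc(OC)c1OC`: 57%
Compound 2 `COc1ccc(-c2cc(/C=C/C(=O)c3ccc(OC)c(OC)c3)[nH]n2)cc1`: 70%

Among the measured compounds shown here, in a functional assay on KM12 cells (Homo sapiens) for cytotoxicity, read by sulforhodamine B assay, with a stated time of 48 h, tested at 1 uM (a higher number here means a weaker effect of the compound at the concentration tested, a lower number a stronger effect), compound 1 gives 57%, the lower of the two numbers so far; compound 2 gives 70%, which lies beyond the scatter above it. Compound 3 `COc1cc(-c2cc(/C=C/C(=O)c3ccc(Cl)c(Cl)c3)[nH]n2)cc(OC)c1OC` has not been measured yet. It differs from compound 1 in a single place: 3,4-dichlorophenyl in place of 4-aminophenyl on a carbonyl carbon. For the measured compounds named here, no measured pair shows a change of this kind, so the expected step in this assay is a number 1 percentage points higher from compound 1 to compound 3 (within the scatter), roughly no further than the scatter in either direction. Compound 3 is therefore expected to give 58%, with a plausible range from 35% to 85%.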

Compound 3, a percentage reported as activity, at one concentration (the size of the read-out at that concentration, not a potency): 85%
Compound 3: the middle estimate sits 27 percentage points below what was measured; measured number inside the range.
By their numbers in this assay, from the lowest: compound 1; then compound 2; then compound 3.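

With the same core, 3,4-dichlorophenyl in place of 4-aminophenyl on the carbonyl carbon gives a number 28 percentage points higher from compound 1 to compound 3 (beyond the scatter) in this assay and so a weaker effect at the concentration tested. This single-place comparison shows that the group on this carbonyl carbon can change the result, and that these two rings are not interchangeable here. No measurement available explains the step.

From the compounds shown here alone, it remains open whether losing the amine or gaining the chlorines accounts for the change. A plain phenyl at this place, carrying neither group, would help separate the two.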